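Aryl ether variation at the end of the series

This account rests on a few compounds, and the source may have more. Where it says the series, first, only, none or still open, it means among the compounds named here.

Measured so far in a functional assay on Jurkat cells (Homo sapiens); a higher number here means a weaker inhibitor, a lower number a stronger inhibitor:
- compound 1 `CC(C)[C@H](NC(=O)COc1cccc2ccccc12)C(=O)N[C@@H](CC(=O)O)C(=O)COc1ccccc1C(F)(F)F` gives > 100000 nM, a limit of the assay.
- compound 2 `CC(C)[C@H](NC(=O)COc1cccc2ccccc12)C(=O)N[C@@H](CC(=O)O)C(=O)COc1ccc(OC(F)(F)F)cc1` gives 29100 nM.
- compound 3 `CC(C)[C@H](NC(=O)COc1cccc2ccccc12)C(=O)N[C@@H](CC(=O)O)C(=O)COc1cccc(F)c1` gives > 100000 nM, a limit of the assay.

Compound 1 thus stands at the limit of > 100000 nM in this assay, at which 2 of the 3 values shown sit, with no number of its own. The step to compound 4 `CC(C)[C@H](NC(=O)COc1cccc2ccccc12)C(=O)N[C@@H](CC(=O)O)C(=O)COc1c(F)cccc1F` is 2,6-difluorophenyl in place of 2-(trifluoromethyl)phenyl on an oxygen on a saturated carbon.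

Two measured steps at the same place bear on it. There was an at least 3.4-fold lower number from compound 1 to compound 2 (0.53 log units; beyond the scatter), and in the opposite sense an at least 3.4-fold higher number from compound 2 to compound 3 (0.53 log units; beyond the scatter); the remaining pair shows a step that the two limits leave unreadable from compound 1 to compound 3. Among the compounds with values here, only one of the three rings so far yields a number, and both fluorine-bearing and trifluoromethyl-bearing rings sit at the limit. For compound 4 the expectation is therefore a step of a number no higher from compound 1 to compound 4 (the limit leaves the size open), that is none beyond the scatter, with the limit the likeliest outcome. Compound 4 is estimated at 100000 nM, within 30000 nM to 300000 nM.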

Compound 4, half-maximal inhibitory concentration: 2040 nM
Estimate against measurement, compound 4: 49-fold (1.69 log units) above; measured number below the stated range.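

In this assay, this place on the oxygen can carry far stronger inhibition than the earlier rings suggested, with an at least 49-fold lower number from compound 1 to compound 4 (1.69 log units; beyond the scatter) and an at least 49-fold lower number from compound 3 to compound 4 (1.69 log units; beyond the scatter). Both of those steps are bounds, since compounds 1 and 3 have no number of their own: the limit of > 100000 nM in this assay, at which 2 of the 4 values shown sit. Against the only earlier ring with a number there is a 14-fold lower number from compound 2 to compound 4 (1.15 log units; beyond the scatter), which makes compound 4 the strongest inhibitor shown, while compound 3, also fluorine-bearing, stays at its limit.

As far as these compounds go, whether an unsubstituted phenyl or a pyridine ring at this place would match compound 4 remains open. So does whether the gain would persist with a change elsewhere on the shared core.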